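The source may report more compounds than this note shows. Statements on the series, on what has been measured and on what is new or still open speak of the compounds shown alone.

In a functional assay on the whole organism for inhibition, with Rattus norvegicus as the target, at a dose of 10 mg/kg by the oral route (on this read-out higher numbers stand for a stronger effect at the one dose given and lower numbers for a weaker effect), compound 1 `COc1cccc(C(=O)Nc2nn[nH]n2)n1` gives 58%, compound 2 `CCCCc1cccc(C(=O)Nc2nn[nH]n2)n1` gives 18%, and compound 3 `O=C(Nc1nn[nH]n1)c1cccc(Oc2ccccc2)n1` gives 0%. Compound 3 therefore stands lowest of the three, and both steps that lead down to it are beyond the scatter. The next change turns compound 3 into compound 4 `O=C(Nc1nn[nH]n1)c1cccc(Cl)n1`: chloro in place of phenoxy on an aromatic carbon. Within the data shown here, two measured steps bear on this. The step of a number 58 percentage points lower from compound 1 to compound 3 (beyond the scatter) shows that putting phenyl in place of methyl on the oxygen wiped out the effect, and the step of a number 18 percentage points lower from compound 2 to compound 3 (beyond the scatter) shows a smaller loss when phenoxy replaced butyl. Taking phenoxy away again and leaving only chloro is therefore expected to bring part of the effect back, as a rise of about a number 35 percentage points higher from compound 3 to compound 4 (beyond the scatter). Compound 4 is expected to give 35%, most likely between 10% and 60%.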

Compound 4, a percentage reported as inhibition, in the whole organism at one dose (the size of the read-out at that dose, not a potency): 13%
Compound 4: middle estimate off by 22 percentage points, on the high side; measured number inside the range.
By their numbers in this assay, from the lowest: compound 3; then compounds 4 and 2 (each within the scatter of the next); then compound 1.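

Chloro at this position brings back only a little of the effect lost with phenoxy, giving a number 13 percentage points higher from compound 3 to compound 4 (beyond the scatter) in this assay. Chloro and butyl cannot be told apart here, with a number 5 percentage points lower from compound 2 to compound 4 (within the scatter), whereas methoxy stands clear of chloro, with a number 45 percentage points lower from compound 1 to compound 4 (beyond the scatter). Nothing available explains why methoxy stands apart from the other groups at this position.

From the compounds shown here alone, it remains open whether ethoxy or an amine in this place would come nearer to methoxy or to chloro. Readings at a single dose also leave the potency of these compounds open.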